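The source may report more compounds than this note shows. Statements on the series, on what has been measured and on what is new or still open speak of the compounds shown alone.

In a functional assay on FM3A cells (Mus musculus), with a stated time of 2 days (a higher number here means a weaker inhibitor, a lower number a stronger inhibitor), three related compounds have been measured so far. Compound 1 `O=C(Nc1ccn([C@H]2OCC=CC2=O)c(=O)n1)c1ccccc1` gives 62000 nM, compound 3 `O=C1C=CCO[C@@H]1n1ccc(O)nc1=O` gives 121000 nM, and compound 2 `C=C1[C@H](O)[C@H](O)CO[C@@H]1n1cc(C)c(O)nc1=O` gives 775000 nM. Compound 3 thus lies within the usual scatter of compound 1 and is clearly a stronger inhibitor than compound 2. Compound 4 `Cc1cn([C@H]2OCC=CC2=O)c(=O)nc1O` is compound 3 with methyl in place of hydrogen on an aromatic carbon. Among the measured compounds shown here, no measured pair shows this change on its own, so there is no direct guide, and no shift beyond the scatter in this assay is expected. The expected change is small, estimated as a 1.2-fold higher number from compound 3 to compound 4 (0.06 log units; within the scatter). For compound 4 the estimated value is 140000 nM, with an expected range of 55000 nM to 350000 nM.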

Compound 4, half-maximal inhibitory concentration: 77000 nM
Compound 4: the middle estimate sits 1.8-fold (0.26 log units) above what was measured; the range from low to high includes it.
By their numbers in this assay, from the lowest: compounds 1, 4 and 3 (each within the scatter of the next); then compound 2.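

In this assay, methyl in place of hydrogen on this aromatic carbon, ortho to a hydroxy group, gives a step that can now be read on its own (a 1.6-fold lower number from compound 3 to compound 4 (0.20 log units; within the scatter)). This first single-change pair at the position shows that the extra carbon brings no shift beyond the scatter, so the position accepts a methyl with neither a clear loss nor a clear gain. Nothing available explains this result. Still open, as far as these compounds go, is how a longer chain such as propyl, an amine or a fluorine atom at this position would compare. Also open, from the compounds shown here alone, is whether methyl would give a similar step on the core of compound 1.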